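The source may hold more compounds than are shown below. What is called first, only, known or untested is meant among the compounds shown, and "the series" means these compounds.

Of the compounds shown here, two have been tested for cytotoxicity on mouse fibroblast cells. Compound 1 `COc1ccc(NCc2cncn2Cc2ccc(-c3ccccc3)cc2N)cc1-c1ccccc1` is one of them. In a toxicity assay on NIH3T3 cells (Mus musculus) for cytotoxicity, read by resazurin assay (on this read-out lower numbers stand for an effect already at smaller amounts and higher numbers for an effect only at larger amounts of compound), compound 1 reaches only the limit of the assay, > 1000 nM, and no number beyond it. Within the data shown here, compound 2 `COC(=O)c1ccc(NCc2cncn2Cc2ccccc2Cl)cc1-c1ccccc1` is the other, and it is the only compound of the two for which an actual number exists: in this assay compound 2 gives 10000 nM. The next compound, compound 3 `COC(=O)c1ccc(NCc2cncn2Cc2ccccc2[N+](=O)[O-])cc1-c1ccccc1`, is not yet measured and differs from compound 2 in one place (nitro in place of chloro on an aromatic carbon). Among the measured compounds shown here, no measured pair separates these two groups here, so the step can only be expected, not read off. The expected step from compound 2 to compound 3 in this assay is small, no change at the digits printed from compound 2 to compound 3 (within the scatter), in either direction no more than the usual scatter. For compound 3 the value expected in this assay is 10000 nM, with a range from 4000 nM to 25000 nM.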

Compound 3, half-maximal effective concentration: 10000 nM
Compound 3: middle estimate and measured number agree at the digits printed; the measured number falls inside the stated range.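

In this assay, among these compounds, the exchange of chloro for nitro gives no change at the digits printed from compound 2 to compound 3 (within the scatter), the first step that can be read between two compounds differing in one place. At this position, on an aromatic carbon ortho to a large group, the swap from 2-chlorobenzyl to 2-nitrobenzyl brings more heavy atoms and two hydrogen-bond acceptors, yet the read-out does not move beyond the scatter. Compound 1 remains a limit and offers no number for comparison: the limit of > 1000 nM in this assay, at which 1 of the 3 values shown sits.

Going by these compounds, whether other groups at this position, such as a carboxylic acid or a nitrile, would read the same stays open. A single pair also cannot tell whether the exchange of chloro for nitro would give the same result at another place on that ring.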